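The compounds below may be only part of what the source reports. "The series", "measured", "known", "first", "only" and "open" are said of these compounds alone.

Measured so far in an ADME assay on microsomes from liver (Rattus norvegicus) for metabolic stability, with a stated time of 10 min; on this read-out higher numbers stand for a more stable compound and lower numbers for a less stable compound:
- compound 1 `CC(C)NCCS(=O)(=O)NC(=O)c1ccc(Nc2nc(NC3(c4ccc(Cl)cc4)CC3)nc(OCC(F)(F)F)n2)cc1` — 100%
- compound 2 `CC(C)NC(=O)NCCS(=O)(=O)NC(=O)c1ccc(Nc2nc(NC3(c4ccc(Cl)cc4)CC3)nc(OCC(F)(F)F)n2)cc1` — 97%

For the measured compounds named here, compound 2 holds the lower of the two numbers in this assay, but its only neighbour is within the scatter: the single measured step, a number 3 percentage points lower from compound 1 to compound 2 (within the scatter), shows no real change, so both compounds sit near the top of the read-out.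

Compound 3 `CN(C)S(=O)(=O)NC(=O)c1ccc(Nc2nc(NC3(c4ccc(Cl)cc4)CC3)nc(OCC(F)(F)F)n2)cc1` is the next step. It differs from compound 2 in one place: dimethylamino in place of 2-((isopropylcarbamoyl)amino)ethyl on a sulfonyl sulfur. The measured step exchanged only the substituent on the amine nitrogen at the far end of that same chain, whereas this change removes the whole chain together with that nitrogen and puts dimethylamino on the sulfonyl sulfur. Going by the values given here, it is therefore a larger edit than anything measured, and no step on this series bears on it directly. What can be said is that the two measured compounds lie near the ceiling regardless of what the chain carries, which gives no ground to expect a drop beyond the scatter, while leaving some room for one.

Compound 3 is expected to remain near the top, with a step of about a number 4 percentage points lower from compound 2 to compound 3 (within the scatter) in this assay. The estimate for compound 3 is 93%, with a range from 72% to 100%.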

Compound 3, percent of the compound remaining: 76%
For compound 3 the middle estimate is 17 percentage points above the measured one; measured number inside the range.
By their numbers in this assay, from the lowest: compound 3; then compounds 2 and 1 (each within the scatter of the next).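

In this assay the group on the sulfonyl sulfur does affect the read-out: a number 21 percentage points lower from compound 2 to compound 3 (beyond the scatter), and a number 24 percentage points lower from compound 1 to compound 3 (beyond the scatter). The earlier step at the far end of the chain, a number 3 percentage points lower from compound 1 to compound 2 (within the scatter), gave no sign of this, so this position tolerates an exchange at the end of the chain but not every replacement of the whole chain. Compounds with 2-(isopropylamino)ethyl or 2-((isopropylcarbamoyl)amino)ethyl on this sulfur both stand clearly higher than the compound with dimethylamino, while nothing available accounts for the difference.

The compounds shown leave open whether the lower number goes with losing the ethyl chain or with having an amine nitrogen directly on the sulfonyl sulfur; a 2-(dimethylamino)ethyl chain and a plain methyl group on that sulfur would separate these two readings. Also open, from the compounds shown here alone, is how a cyclic amine such as morpholine or a smaller amino group such as methylamino would compare with dimethylamino at this place.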